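An isopropyl pyrazole on the sulfonyl sulfur

A few compounds are considered here, and "the series" means these few. Any claim that something is new, unique, unknown or untested is made for them only; others in the source may bear on it.

Three measured compounds share one core and differ only in the group on a sulfonyl sulfur. In an ADME assay on MDCK cells (Canis lupus familiaris) for permeability, in the apical to basolateral direction (on this read-out higher numbers stand for higher permeability and lower numbers for lower permeability), compound 1 `O=C(NCc1ccc(S(=O)(=O)c2cc(F)cc(F)c2)cc1)c1cc2ccncc2o1` gives 14 10^-6 cm/s and compound 2 `O=C(NCc1ccc(S(=O)(=O)C2CCOCC2)cc1)c1cc2ccncc2o1` gives 12 10^-6 cm/s while compound 3 `CC(C)N1CCC(S(=O)(=O)c2ccc(CNC(=O)c3cc4ccncc4o3)cc2)CC1` gives 8 10^-6 cm/s on the same scale. Compound 3 thus stands within the scatter of both other compounds, and the three numbers cannot be ranked.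

Compound 4 `CC(C)n1cc(S(=O)(=O)c2ccc(CNC(=O)c3cc4ccncc4o3)cc2)cn1` has not yet been measured. It differs from compound 3 at the same place, with 1-isopropyl-1H-pyrazol-4-yl in place of 1-isopropylpiperidin-4-yl on a sulfonyl sulfur. Within the data shown here, no measured compound carries this pyrazole group, so the evidence is indirect.

Among the measured compounds shown here, three measured steps bear on the change, all of them replacements on that sulfur. These are a 1.8-fold lower number from compound 1 to compound 3 (0.24 log units; within the scatter) and a 1.5-fold lower number from compound 2 to compound 3 (0.18 log units; within the scatter) and also a 1.2-fold lower number from compound 1 to compound 2 (0.07 log units; within the scatter) and each one stays within the scatter. The aromatic group of compound 1 and the non-aromatic groups of compound 2 and compound 3 therefore give no separable numbers. No step beyond the scatter is expected in this assay for this replacement. The estimated step is a 1.5-fold higher number from compound 3 to compound 4 (0.18 log units; within the scatter) and it remains within that scatter. Compound 4 is expected at about 12 10^-6 cm/s with an estimated range from 6 10^-6 cm/s to 22 10^-6 cm/s in this measurement.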

Compound 4, apparent permeability: 14 10^-6 cm/s
Beside the measured number, compound 4's estimate is 1.2-fold (0.07 log units) below it, and the stated range covers the measured number.
By their numbers in this assay, from the lowest: compounds 3, 2, 1 and 4 (each within the scatter of the next).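

In this assay, the 1-isopropyl-1H-pyrazol-4-yl group on the sulfonyl sulfur gives a 1.8-fold higher number from compound 3 to compound 4 (0.24 log units; within the scatter), so the five-membered aromatic ring and the six-membered non-aromatic ring of 1-isopropylpiperidin-4-yl cannot be told apart at this position. The comparisons with the other two groups read the same way, with a 1.2-fold higher number from compound 2 to compound 4 (0.07 log units; within the scatter) and with no change at the digits printed from compound 1 to compound 4 (within the scatter). All four groups on this sulfur, two aromatic and two non-aromatic, now lie within the scatter of one another, which widens the range of groups at this position that give no separable number in this read-out. The data given include no measurement that would account for these numbers.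

The compounds leave open whether any group at this position can produce a step beyond the scatter, since all four groups shown are rings; a carboxylic acid or an open butyl chain on the sulfonyl sulfur would test this. They also leave open what the isopropyl contributes, which a pyrazole carrying a methyl in its place would address.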